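This account rests on a few compounds, and the source may have more. Where it says the series, first, only, none or still open, it means among the compounds named here.

In a functional assay on HEp-2 cells (Homo sapiens) for cytotoxicity, read by sulforhodamine B assay, with a stated time of 48 h (a higher number here means a weaker inhibitor, a lower number a stronger inhibitor), three compounds have been measured:

Compound 1 `O=CCN1N=C(c2ccc3ccccc3c2)CC1c1ccccc1` gives 8400 nM.
Compound 2 `O=CCN1N=C(c2ccc3ccccc3c2)CC1c1cccc(Cl)c1Cl` gives 12500 nM.
Compound 3 `O=CCN1N=C(c2ccc3ccccc3c2)CC1c1cccc(Br)c1` gives 8780 nM.

All three numbers sit within the usual scatter of one another: a 1.0-fold higher number from compound 1 to compound 3 (0.02 log units; within the scatter) and a 1.4-fold lower number from compound 2 to compound 3 (0.15 log units; within the scatter). Compound 4 `O=CCN1N=C(c2ccc3ccccc3c2)CC1/C=C/c1ccccc1` differs from compound 3 in one place: 2-phenylethenyl in place of 3-bromophenyl on a saturated ring carbon. Two measured steps also swap the group on this saturated ring carbon, a 1.5-fold higher number from compound 1 to compound 2 (0.17 log units; within the scatter) and a 1.4-fold lower number from compound 2 to compound 3 (0.15 log units; within the scatter), and neither moved beyond the scatter. Going by the values given here, no measured step tests a 2-phenylethenyl group, so the expectation rests on those swaps alone. In this assay compound 4 is therefore expected to show a 1.0-fold higher number from compound 3 to compound 4 (0.01 log units; within the scatter). The estimate for compound 4 is 9000 nM, with a range from 3000 nM to 30000 nM.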

Compound 4, half-maximal inhibitory concentration: 20100 nM
Estimate against measurement, compound 4: 2.2-fold (0.35 log units) below, and the stated range covers the measured number.
By their numbers in this assay, from the lowest: compounds 1, 3, 2 and 4 (each within the scatter of the next, the first and the last beyond it).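

In this assay this saturated ring carbon proves not to be indifferent to its group, since 2-phenylethenyl gives a 2.3-fold higher number from compound 3 to compound 4 (0.36 log units; beyond the scatter) and also a 2.4-fold higher number from compound 1 to compound 4 (0.38 log units; beyond the scatter) as modest steps toward a weaker inhibitor. Compound 2 goes against this, with a 1.6-fold higher number from compound 2 to compound 4 (0.21 log units; within the scatter) as a step that cannot be told from noise. No measurement shown bears on what lies behind these steps.

From the compounds shown here alone, whether a longer chain, an amine or a carboxylic acid on this carbon would shift the number further stays open. So does whether a saturated two-carbon link in place of the double bond would behave like 2-phenylethenyl.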